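The compounds below may be only part of what the source reports. "The series", "measured", "known", "first", "only" and "open" are said of these compounds alone.

Measured so far:
Compound 1 `COC(=O)CC[C@@H]1NC(=O)[C@@H](C)NC(=O)[C@@H]2Cc3ccc(OC)c(c3)Oc3ccc(cc3)C[C@@H](C(=O)N2C)N(C)C(=O)[C@H](C)NC(=O)[C@H](Cc2ccc(OC)cc2)N(C)C1=O`: in a functional assay on P388 cells (Mus musculus) for cytotoxicity (a lower number here means a stronger inhibitor, a higher number a weaker inhibitor), compound 1 gives 58.9 nM.
Compound 2 `COc1ccc(C[C@H]2C(=O)N[C@@H](C)C(=O)N(C)[C@H]3Cc4ccc(cc4)Oc4cc(ccc4OC)C[C@@H](C(=O)N[C@H](C)C(=O)N[C@@H](CCCO)C(=O)N2C)N(C)C3=O)cc1`: in this assay compound 2 gives 174 nM.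
Compound 3 `COc1ccc(C[C@H]2C(=O)N[C@@H](C)C(=O)N(C)[C@H]3Cc4ccc(cc4)Oc4cc(ccc4OC)C[C@@H](C(=O)N[C@H](C)C(=O)N[C@@H](CCCN=[N+]=[N-])C(=O)N2C)N(C)C3=O)cc1`: in this assay compound 3 gives 35.5 nM.

Compound 2 carries the highest number of the three. The path to it reads a 3.0-fold higher number from compound 1 to compound 2 (0.47 log units; beyond the scatter), and away from it a 4.9-fold lower number from compound 2 to compound 3 (0.69 log units; beyond the scatter); both steps are modest but beyond the scatter. Compound 1 and compound 3, by contrast, sit close together: a 1.7-fold lower number from compound 1 to compound 3 (0.22 log units; within the scatter).

Compound 4 `COc1ccc(C[C@H]2C(=O)N[C@@H](C)C(=O)N(C)[C@H]3Cc4ccc(cc4)Oc4cc(ccc4OC)C[C@@H](C(=O)N[C@H](C)C(=O)N[C@@H](CCO)C(=O)N2C)N(C)C3=O)cc1` is compound 2 with its side chain shortened by one carbon: hydroxy in place of hydroxymethyl on a saturated chain carbon, two bonds along the chain from a saturated ring carbon.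

For the measured compounds named here, no measured step shortens this chain; the two steps that involve compound 2 exchange the group at its end instead. Replacing hydroxy by azido gave a 4.9-fold lower number from compound 2 to compound 3 (0.69 log units; beyond the scatter), and replacing methoxycarbonyl by hydroxymethyl gave a 3.0-fold higher number from compound 1 to compound 2 (0.47 log units; beyond the scatter). The present change keeps the hydroxy and only removes one carbon, a smaller alteration than either of those, so no step beyond the scatter is expected, with the range left wide in both directions. Compound 4 is therefore expected at 160 nM, between 60 nM and 420 nM. This corresponds to an expected step of a 1.1-fold lower number from compound 2 to compound 4 (0.04 log units; within the scatter).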

Compound 4, half-maximal inhibitory concentration: 60.3 nM
Estimate against measurement, compound 4: 2.7-fold (0.42 log units) above; measured number inside the range.
By their numbers in this assay, from the lowest: compounds 3, 1 and 4 (each within the scatter of the next); then compound 2.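

Working notes: with the hydroxy kept, shortening 3-hydroxypropyl to 2-hydroxyethyl in this assay gives a 2.9-fold lower number from compound 2 to compound 4 (0.46 log units; beyond the scatter) and thus shows that chain length alone can move the number at this position beyond the scatter, which the earlier steps could not show because each exchanged the end group. The 2-hydroxyethyl compound does not stand apart from the other two chains, with a 1.0-fold higher number from compound 1 to compound 4 (0.01 log units; within the scatter) and a 1.7-fold higher number from compound 3 to compound 4 (0.23 log units; within the scatter) both printed as within the scatter, so among these four only compound 2 stands apart and a terminal hydroxy does not by itself go with a higher number. No measurement shown bears on why one extra carbon has this effect.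

Open, as far as these compounds go, is whether the higher number is particular to the 3-hydroxypropyl chain or would recur with a longer chain ending in hydroxy, and whether an amine or a carboxylic acid at the chain end would fall within the scatter of compound 1, compound 3 and compound 4. Two hydroxy chain lengths are too few to state any trend with length.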